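A few compounds are considered here, and "the series" means these few. Any claim that something is new, unique, unknown or untested is made for them only; others in the source may bear on it.

Measured so far:
Compound 1, `Fc1ccc(COc2cccc(-c3cn(C4CN5CCC4CC5)nn3)c2)cc1`: in an assay on HEK293 cells for displacement of a labelled ligand from Neuronal acetylcholine receptor; alpha3/beta4 (Homo sapiens), read by scintillation counting, with a stated time of 120 min (a lower number here means a stronger inhibitor, a higher number a weaker inhibitor), compound 1 gives 13.9 nM.
Compound 2, `Fc1ccc(-c2cn([C@@H]3CN4CCC3CC4)nn2)cc1`: compound 2 gives 3.09 nM.
Compound 3, `Oc1ccc(-c2cn([C@@H]3CN4CCC3CC4)nn2)cc1`: compound 3 gives 2.48 nM.

Compound 3 has the lowest of the three numbers in this assay, but its nearest neighbour, compound 2, is within the scatter of it, and only compound 1 is clearly apart. Among the compounds with values here, the single measured step, a 1.2-fold lower number from compound 2 to compound 3 (0.10 log units; within the scatter), swaps one aromatic substituent and changes little.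

Compound 4, `Oc1ccc(-c2cn([C@H]3CN4CCC3CC4)nn2)cc1`, differs from compound 3 in no atom or bond: the two compounds have the same atoms and bonds; at least one stereo element is drawn with a configuration in one of them and without one in the other: 1 of 3 stereo elements differ; a stereocentre at a saturated ring carbon is drawn S in compound 3 and R in compound 4. Within the data shown here, none of the measured steps touches a stereocentre, so nothing here tells how large such a change is; compound 1 is drawn without a configuration at that carbon and its value is the only indirect hint. The expectation is therefore wide, leaning towards a weaker binder, as a 6.0-fold higher number from compound 3 to compound 4 (0.78 log units; beyond the scatter). Compound 4 is estimated at 15 nM, with a range from 3 nM to 80 nM.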

Compound 4, inhibition constant: 138 nM
Estimate against measurement, compound 4: 9.2-fold (0.96 log units) below; the whole stated range lies below it.
By their numbers in this assay, from the lowest: compounds 3 and 2 (each within the scatter of the next); then compound 1; then compound 4.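

Inverting one stereocentre at a saturated ring carbon, with no atom or bond changed, gives a large step in this assay: a 56-fold higher number from compound 3 to compound 4 (1.75 log units; beyond the scatter). The earlier step, a 1.2-fold lower number from compound 2 to compound 3 (0.10 log units; within the scatter), showed that swapping fluoro for hydroxy on the aromatic carbon changes little, so between these compounds the configuration at this ring carbon matters far more than that substituent. The S drawing goes with the lower number, and the one structural difference to which the gap can be tied is the one at this carbon: the fact that one of compounds 3 and 4 is drawn with a defined configuration and the other without, at the place where they differ

From the compounds shown here alone, it remains open whether the R form responds to the aromatic substituent as little as the S form does. Going by these compounds, it is also open how either form would behave with an amine or a carboxylic acid in place of the hydroxy.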